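Fluoro for Hydrogen on the Shared Core

The source may hold more compounds than are shown below. What is called first, only, known or untested is meant among the compounds shown, and "the series" means these compounds.

The series is followed in a functional assay on CCRF-CEM cells (Homo sapiens) for inhibition; a higher number here means a weaker inhibitor, a lower number a stronger inhibitor. Compound 1 `CC1(CO)OCC(n2cc(F)c(N)nc2=O)O1` reaches only a limit of the assay in this assay, > 100000 nM. Compound 2 `CC1(CO)OC[C@@H](n2ccc(N)nc2=O)O1` likewise gives only a limit in this assay, > 100000 nM. For the measured compounds named here, compound 2 thus stands at the limit, with no number of its own, as summed up by the limit of > 100000 nM in this assay, at which 2 of the 2 values shown sit, so no measured step separates the two compounds and neither can be placed relative to the other. Compound 3 `CC1(CO)OC[C@@H](n2cc(F)c(N)nc2=O)O1` is not yet measured. It differs from compound 2 by fluoro in place of hydrogen on an aromatic carbon. With both known values sitting at the limit, no step beyond the scatter is expected in either direction. The step from compound 2 to compound 3 is therefore estimated as a step that the limit leaves unreadable from compound 2 to compound 3. For compound 3 in this assay the expected value is 150000 nM, within 50000 nM to 500000 nM, most likely again reported only as a limit.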

Compound 3, half-maximal inhibitory concentration: > 100000 nM
Compound 3 was reported as a limit (the forecaster's own chance of this, stated with the estimate: 85%); the middle value does not contradict the limit.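

Compound 3 gives only a limit in this assay, > 100000 nM, so no step to it from compound 1 or compound 2 can be read: the limit of > 100000 nM in this assay, at which 3 of the 3 values shown sit.

The compounds shown leave open whether fluoro in place of hydrogen on an aromatic carbon, or the configuration drawn at the saturated ring carbon, changes inhibition in this assay at all.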